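The source may report more compounds than this note shows. Statements on the series, on what has been measured and on what is new or still open speak of the compounds shown alone.

Measured compounds:
compound 1 `COc1cc2c(Oc3ccc(NC(=O)N/N=C/c4ccc(F)cc4Cl)cc3F)ccnc2cc1OCCCN1CCCCC1`; in a functional assay on MKN-45 cells (Homo sapiens) for cytotoxicity, read by MTT assay, with a stated time of 72 h (on this read-out higher numbers stand for weaker inhibition and lower numbers for stronger inhibition), compound 1 gives 270 nM.
compound 2 `COc1cc2c(Oc3ccc(NC(=O)N/N=C/c4ccc(N(C)C)cc4)cc3F)ccnc2cc1OCCCN1CCCCC1`; in this assay compound 2 gives 870 nM.

Compound 2 stands at the highest number of the two; the step of a 3.2-fold higher number from compound 1 to compound 2 (0.51 log units; beyond the scatter) separates it from compound 1. Compound 3 `COc1cc2c(Oc3ccc(NC(=O)N/N=C/c4cc5ccccc5[nH]4)cc3F)ccnc2cc1OCCCN1CCCCC1` differs from compound 2 in one place: 1H-indol-2-yl in place of 4-(dimethylamino)phenyl on a carbon with a double bond to nitrogen. Within the data shown here, no measured step exchanges the aryl group on this carbon for a bicyclic one, so nothing bears directly on the change. Among the measured compounds shown here, the only step available, a 3.2-fold higher number from compound 1 to compound 2 (0.51 log units; beyond the scatter), shows that swapping the group on this carbon shifts the number modestly, beyond the scatter. A modest step is therefore expected in this assay, more likely downward than upward, given that compound 2 holds the higher of the two numbers, as the expected step of a 2.2-fold lower number from compound 2 to compound 3 (0.34 log units; beyond the scatter) states. Compound 3 is expected to give about 400 nM in this assay, with a range from 120 nM to 1400 nM.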

Compound 3, half-maximal inhibitory concentration: 830 nM
Compound 3: the middle estimate sits 2.1-fold (0.32 log units) below what was measured; low and high end bracket the measured number.
By their numbers in this assay, from the lowest: compound 1; then compounds 3 and 2 (each within the scatter of the next).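

In this assay, 1H-indol-2-yl and 4-(dimethylamino)phenyl on a carbon with a double bond to nitrogen cannot be told apart, with a 1.0-fold lower number from compound 2 to compound 3 (0.02 log units; within the scatter). The exchange of one six-membered aromatic ring for a fused pair of aromatic rings, with a hydrogen-bond donor entering and a hydrogen-bond acceptor leaving, therefore brings no readable change at this position, while 2-chloro-4-fluorophenyl stays apart from the indole, with a 3.1-fold higher number from compound 1 to compound 3 (0.49 log units; beyond the scatter). Nothing available explains either step.

Whether the chlorine, the fluorine or both account for the gap between compound 1 and the other two compounds remains open. Also open, from the compounds shown here alone, is where a plain phenyl, a pyridyl or a phenyl bearing a carboxylic acid would fall on this carbon.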